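Swapping a Methylsulfonyl Ether for a 4-Fluorobenzyl Ether

The compounds below may be only part of what the source reports. "The series", "measured", "known", "first", "only" and "open" are said of these compounds alone.

Measured compounds:
compound 1, `COc1cc(-c2nc3ccccc3c(=O)[nH]2)ccc1OCc1ccc(Cl)cc1Cl`: 36.6%
compound 2, `COc1cc(-c2nc3ccccc3c(=O)[nH]2)ccc1OS(C)(=O)=O`: 54.2%

For the measured compounds named here, in an ADME assay on HEK293 cells for inhibition of cytochrome P450 1A1 (Homo sapiens), with stated times of 30 min and 60 min, tested at 10 uM (on this read-out higher numbers stand for more inhibition at the one concentration tested (going by the name of the read-out) and lower numbers for less inhibition), compound 2 gives 54.2%, the higher of the two numbers so far; compound 1 gives 36.6%, and the single measured step, a number 17.6 percentage points higher from compound 1 to compound 2 (beyond the scatter), sets compound 2 apart beyond the scatter. Compound 3 `COc1cc(-c2nc3ccccc3c(=O)[nH]2)ccc1OCc1ccc(F)cc1` has not yet been measured. It differs from compound 2 in one place: 4-fluorobenzyl in place of methylsulfonyl on an oxygen on an aromatic ring. Going by the values given here, the only measured step that bears on this change is a number 17.6 percentage points higher from compound 1 to compound 2 (beyond the scatter), which concerned the same oxygen and the same pair of group types, benzyl against methylsulfonyl, but ran in the opposite direction and carried 2,4-dichlorobenzyl instead of 4-fluorobenzyl. Reading that step backwards, compound 3 is expected to sit below compound 2 by a modest margin, a number 14.2 percentage points lower from compound 2 to compound 3 (beyond the scatter). Compound 3 is therefore estimated at 40%, with a range from 25% to 55%.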

Compound 3, a percentage reported as inhibition, at one concentration (the size of the read-out at that concentration, not a potency): 11.8%
Compound 3: the middle estimate sits 28.2 percentage points above what was measured; measured number below the stated range.
By their numbers in this assay, from the lowest: compound 3; then compound 1; then compound 2.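

Compound 3 shows that in this assay the outcome at this oxygen is not settled by benzyl against methylsulfonyl alone, since the 4-fluorobenzyl group gives a large drop, with a number 42.4 percentage points lower from compound 2 to compound 3 (beyond the scatter) as the step. Both benzyl ethers now sit under the methylsulfonyl compound, and no compound shown goes against that, yet the benzyl groups also part from each other, with a number 24.8 percentage points lower from compound 1 to compound 3 (beyond the scatter) for the change of ring substituents. Nothing shown here offers a reason for either step.

Still open, from the compounds shown here alone, is how much of the gap between the two benzyl groups belongs to the fluorine and how much to the two chlorines, which a plain benzyl group would help to separate. Going by these compounds, it is also open how this oxygen would respond to a smaller group such as acetyl, or to a chain ending in an amine or a carboxylic acid.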